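Swapping an acetylphenyl for a methylphenyl on the shared core

A few compounds are considered here, and "the series" means these few. Any claim that something is new, unique, unknown or untested is made for them only; others in the source may bear on it.

Compound 1 `COc1cc(-c2ccnc3c(-c4ccc(C)cc4)cnn23)cc(OC)c1OC`: > 10000 nM
Compound 2 `COc1cc(-c2ccnc3cc(-c4ccc(C(C)=O)cc4)nn23)cc(OC)c1OC`: 1810 nM

In a functional assay on HeLa cells (Homo sapiens) for inhibition, read by CCK-8 assay, with a stated time of 48 h (a higher number here means a weaker inhibitor, a lower number a stronger inhibitor), compound 1 reaches only a limit, > 10000 nM, and not a number. Compound 2 gives 1810 nM in this assay. Within the data shown here, that is the only number among the two results; the other one sits at the limit of > 10000 nM in this assay, at which 1 of the 2 values shown sits. Compound 1 and compound 2 differ in more than one place, so the two values say nothing about any single change.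

Compound 3 `COc1cc(-c2ccnc3cc(-c4cccc(C)c4)nn23)cc(OC)c1OC` has not yet been measured. It differs from compound 2 in one place: 3-methylphenyl in place of 4-acetylphenyl on an aromatic carbon. Among the measured compounds shown here, no comparable step between measured compounds exists, so the expectation rests on the structures alone. Compound 3 is expected to lose some strength, with a step of a 2.8-fold higher number from compound 2 to compound 3 (0.44 log units; beyond the scatter) in this assay, beyond the usual scatter. Compound 3 is estimated at 5000 nM in this assay, with a range from 1500 nM to 15000 nM.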

Compound 3, half-maximal inhibitory concentration: 4230 nM
Compound 3: the middle estimate sits 1.2-fold (0.07 log units) above what was measured; the range from low to high includes it.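

Among these compounds, replacing 4-acetylphenyl with 3-methylphenyl on an aromatic carbon of the five-membered aromatic ring gives the first single-change comparison on the shared core: in this assay, the swap brings a 2.3-fold higher number from compound 2 to compound 3 (0.37 log units; beyond the scatter), so what this position carries affects the result. Even without the acetyl group's carbonyl, compound 3 still gives a number, 4230 nM, so a carbonyl at this position is not required for a measurable value in this assay. Nothing shown explains the step.

The swap changes both the substituent and where it sits on the phenyl ring, so the step cannot be assigned to either change alone. Open too, from the compounds shown here alone, is how 3-acetylphenyl, or a phenyl bearing an amine or a carboxylic acid, would read at this position.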